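The source may report more compounds than this note shows. Statements on the series, on what has been measured and on what is new or still open speak of the compounds shown alone.

Measured compounds:
Compound 1, `COc1cc(/C=C/c2ccc(NC(=O)/C=C/c3ccc(O)c(O)c3)cc2)cc(OC)c1`: in a functional assay on HT-29 cells (Homo sapiens) for inhibition, read by MTT assay, with a stated time of 48 h (a lower number here means a stronger inhibitor, a higher number a weaker inhibitor), compound 1 gives 1560 nM.
Compound 2, `COc1cc(/C=C/c2ccc(OC(=O)/C=C/c3ccccc3)cc2)cc(OC)c1`: in this assay compound 2 gives 9050 nM.
Compound 3, `COc1cc(/C=C/c2ccc(OC(=O)/C=C/c3ccc(C(F)(F)F)cc3)cc2)cc(OC)c1`: in this assay compound 3 gives 9090 nM.

Compound 3 stands at the highest of these three numbers. Its nearest neighbour is compound 2, separated from it by a 1.0-fold higher number from compound 2 to compound 3 (0.00 log units; within the scatter), a step that reads as no change at all. Among the compounds with values here, its furthest neighbour is compound 1, whose lower number lies beyond the scatter; compound 1 differs from compound 3 in more than one place, so no single step connects the two.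

Compound 4, `COc1cc(/C=C/c2ccc(OC(=O)/C=C/c3ccc(F)cc3)cc2)cc(OC)c1`, differs from compound 3 by fluoro in place of trifluoromethyl on an aromatic carbon. Within the data shown here, only one measured step touches the same position: a 1.0-fold higher number from compound 2 to compound 3 (0.00 log units; within the scatter), where a trifluoromethyl placed on that carbon left the number where it was. Nothing else among the measured compounds bears on this change. Among the measured compounds shown here, with the one relevant step flat, the expected step is a 1.0-fold lower number from compound 3 to compound 4 (0.00 log units; within the scatter), no movement beyond the scatter. Compound 4 is therefore estimated at 9000 nM in this assay, with a range from 4000 nM to 20000 nM.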

Compound 4, half-maximal inhibitory concentration: 7770 nM
Estimate against measurement, compound 4: 1.2-fold (0.06 log units) above; measured number inside the range.
By their numbers in this assay, from the lowest: compound 1; then compounds 4, 2 and 3 (each within the scatter of the next).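

Hydrogen, fluoro and trifluoromethyl have now all stood on this aromatic carbon in this assay, and the numbers do not tell them apart. Fluoro, a single heavy atom against the four of trifluoromethyl, reads the same as the larger group (a 1.2-fold lower number from compound 3 to compound 4 (0.07 log units; within the scatter)) and the same as hydrogen (a 1.2-fold lower number from compound 2 to compound 4 (0.07 log units; within the scatter)), so the position has shown no response to any of these three occupants. Nothing measured here offers a reason for that flatness.

Trifluoromethyl and fluoro both count no hydrogen-bond donors or acceptors and no net charge, so an amine or a carboxylic acid on this carbon remains an open case. Also open, as far as these compounds go, is whether the position stays flat in the setting of compound 1, which differs from compound 2 in more than one place.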